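The source may report more compounds than this note shows. Statements on the series, on what has been measured and on what is new or still open speak of the compounds shown alone.

Of the compounds shown here, two from this set have so far been tested in a functional assay on PC-3M cells (Homo sapiens) for cytotoxicity, read by MTT assay, with a stated time of 48 h; a higher number here means a weaker inhibitor, a lower number a stronger inhibitor. Compound 1 `Cc1ccc(C(=O)CSc2nnc(C)n2N2C(=O)c3ccccc3C2=O)cc1` reaches only the limit of the test, giving > 200000 nM rather than a number. Compound 2 `CCCc1nnc(SCc2ccccc2)n1N1C(=O)c2ccccc2C1=O` likewise stops at the limit, giving > 200000 nM. Both values therefore sit at one and the same limit, as recorded in the limit of > 200000 nM in this assay, at which 2 of the 2 values shown sit, so compound 2 cannot be placed above or below compound 1 on these numbers; it simply shows no measurable effect up to that limit.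

Compound 3 `CCCc1nnc(SCC(=O)c2ccc(C)cc2)n1N1C(=O)c2ccccc2C1=O` has not yet been tested. Against compound 2 it carries a single change: (4-methylphenyl)carbonyl in place of phenyl on a saturated chain carbon bound to a sulfur. The incoming group is the same one that compound 1 bears on its own chain, and compound 1 also gave only a limit. Among the compounds with values here, no measured pair in this set shows a change of this kind, so nothing points to a gain or a loss beyond the usual scatter, and the expected step that the limit leaves unreadable from compound 2 to compound 3 is none of note. Compound 3 is accordingly estimated at 250000 nM, within 100000 nM to 600000 nM, most probably again reported only as a limit.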

Compound 3, half-maximal inhibitory concentration: > 200000 nM
Compound 3 gave a limit, no number (the forecaster's own chance of this, stated with the estimate: 85%); the middle value does not contradict the limit.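

In this assay compound 3 gives only a limit, > 200000 nM. No step from compound 1 or compound 2 to compound 3 can be read, because all three compounds sit at the same limit: the limit of > 200000 nM in this assay, at which 3 of the 3 values shown sit.

The compounds shown leave open whether any change on the shared core can produce a measurable value in this assay.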